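A few compounds are considered here, and "the series" means these few. Any claim that something is new, unique, unknown or untested is made for them only; others in the source may bear on it.

The series shares the core of compound 1 `COC(=O)/C=C/c1cccc(N(Cc2ccc(-c3ccc(F)c(Cl)c3)cc2)C(=O)C2CCCCC2)c1`, which in an assay on isolated protein with Bile acid receptor (Homo sapiens) as the target (on this read-out lower numbers stand for an effect already at smaller amounts and higher numbers for an effect only at larger amounts of compound), gives 66 nM. Compound 2 `COC(=O)/C=C/c1cccc(N(Cc2ccccc2Br)C(=O)C2CCCCC2)c1` returns only a limit, > 1000 nM, in this assay. Compound 3 `CCOC(=O)/C=C/c1ccc(CN(C(=O)C2CCCCC2)c2cccc(/C=C/C(=O)OC)c2)cc1` also returns only a limit, > 1000 nM, in this assay, so where compound 3 stands is known as a bound and not a number, consistent with the limit of > 1000 nM in this assay, at which 2 of the 3 values shown sit. Within the data shown here, the single measured step, an at least 15-fold higher number from compound 1 to compound 3 (1.18 log units; beyond the scatter), concerns a different change and does not bear on what follows. Compound 4 `COC(=O)/C=C/c1cccc(N(Cc2ccc(/C=C/C(=O)O)cc2)C(=O)C2CCCCC2)c1` differs from compound 3 by hydrogen in place of ethyl on an oxygen next to a carbonyl group. Among the measured compounds shown here, with no measured step on this change, no direction beyond the scatter is expected. Compound 4 is therefore estimated at 2000 nM, within 500 nM to 10000 nM, most likely again a limit. The expected step is a step that the limit leaves unreadable from compound 3 to compound 4.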

Compound 4, half-maximal effective concentration: > 1000 nM
Compound 4 gave a limit, no number; the forecaster's own chance of this, stated with the estimate: 60%; the middle value is on the limit's open side.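

Replacing ethoxycarbonyl with carboxy does not recover a measurable value in this assay: 2-carboxyethenyl in place of 3-chloro-4-fluorophenyl gives an at least 15-fold higher number from compound 1 to compound 4 (1.18 log units; beyond the scatter), a large step like the one seen with 2-(ethoxycarbonyl)ethenyl. The steps joining compound 4 to compound 2 and compound 3 cannot be read, since both ends are limits. Compound 1 remains the only compound with a number, and the rest sit at one bound: the limit of > 1000 nM in this assay, at which 3 of the 4 values shown sit.

Any difference between the ethyl ester and the carboxylic acid stays hidden behind the limits. Also open, from the compounds shown here alone, is whether a simple phenyl or an amine-bearing phenyl on that aromatic carbon would return a number.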